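This account rests on a few compounds, and the source may have more. Where it says the series, first, only, none or still open, it means among the compounds named here.

Working notes on the series, step from compound 1 to compound 4.

Compound 1 `C=CC1=C(C(=O)NCCCCC)C(c2ccc(OC)cc2)OC1` is the anchor of this step. In a functional assay on QGY7701 cells (Homo sapiens) for cytotoxicity, read by MTT assay, with a stated time of 24 h (a higher number here means a weaker inhibitor, a lower number a stronger inhibitor), compound 1 returns only the limit > 100000 nM, which is a limit of the assay and not a number; it is the case described by the limit of > 100000 nM in this assay, at which 1 of the 3 values shown sits. The two numbered values come from the fluorophenyl pair: compound 2 `C=CC1=C(C(=O)Nc2ccccc2OC)C(c2ccc(F)cc2)OC1` gives 52800 nM in this assay, and compound 3 `C=CC1=C(C(=O)Nc2ccc(C)cc2)C(c2ccc(F)cc2)OC1` gives 59200 nM. Among the measured compounds shown here, the single measured step, a 1.1-fold higher number from compound 2 to compound 3 (0.05 log units; within the scatter), exchanges one aromatic amide substituent for another and is within the scatter, so it says little about how an aromatic group in place of a chain would read.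

Compound 4 `C=CC1=C(C(=O)NCc2ccc(C)cc2)C(c2ccc(OC)cc2)OC1` is the target. Its difference from compound 1 is 4-methylphenyl in place of butyl on a saturated chain carbon bound to an amide-type nitrogen. For the measured compounds named here, no measured step covers this kind of change, and compound 1 sits at the limit, so the direction can only be guessed from compound 2 and compound 3 carrying aromatic amide groups and reading below the limit. A step of an at least 1.2-fold lower number from compound 1 to compound 4 (0.09 log units; that floor lies within the scatter) is expected for compound 4, with a real chance the assay again reports only a limit. Compound 4 is estimated at 80000 nM in this assay, between 30000 nM and 200000 nM.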

Compound 4, half-maximal inhibitory concentration: 43100 nM
Beside the measured number, compound 4's estimate is 1.9-fold (0.27 log units) above it; measured number inside the range.
By their numbers in this assay, from the lowest: compounds 4, 2 and 3 (each within the scatter of the next). At a limit, above all of these: compound 1.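

In this assay, among the compounds shown here, the change at this position reads as an at least 2.3-fold lower number from compound 1 to compound 4 (0.36 log units; beyond the scatter), the first step that lies beyond the scatter. It shows that an aromatic ring in place of butyl, on a saturated chain carbon bound to an amide-type nitrogen, brings a compound off the limit, which the earlier step between two aromatic amide groups could not show. The size of this step is only a floor, since compound 1 holds a limit of the assay and not a number: the limit of > 100000 nM in this assay, at which 1 of the 4 values shown sits.

On these data alone, it remains open whether a plain benzyl, a longer chain such as octyl, or a benzyl carrying an amine or a carboxylic acid would read as compound 4 does. Also open, as far as these compounds go, is whether the same change would hold with the fluorophenyl group of compound 2 in place of the methoxyphenyl group.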